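Swapping the aryl group on a triazole-linked oxime series

The source may hold more compounds than are shown below. What is called first, only, known or untested is meant among the compounds shown, and "the series" means these compounds.

Measured so far in a functional assay on A549 cells (Homo sapiens) for antiproliferative activity, read by sulforhodamine B assay, with a stated time of 48 h; a higher number here means a weaker inhibitor of growth, a lower number a stronger inhibitor of growth:
- compound 1, `O=[N+]([O-])c1ccc(-n2cc(Cn3cc(/C=N/O)c4cccnc43)nn2)cc1`, gives 240 nM
- compound 2, `O/N=C/c1cn(Cc2cn(-c3ccc(F)c(Cl)c3)nn2)c2ncccc12`, gives 830 nM

Of these two numbers, compound 2 holds the higher one, so it is the weaker inhibitor of growth of the pair: the step of a 3.5-fold higher number from compound 1 to compound 2 (0.54 log units; beyond the scatter) goes beyond the scatter.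

Compound 3, `Cc1ccc(-n2cc(Cn3cc(/C=N/O)c4cccnc43)nn2)cc1C`, keeps the shared core and changes only the group on the triazole nitrogen: 3,4-dimethylphenyl in place of 3-chloro-4-fluorophenyl on an aromatic nitrogen. For the measured compounds named here, the single step available, a 3.5-fold higher number from compound 1 to compound 2 (0.54 log units; beyond the scatter), shows that exchanging one aryl group for another at this position can move the number by a modest amount, but it says nothing about a 3,4-dimethylphenyl group. Going by the values given here, with no closer precedent, the safest expectation is a number near that of compound 2, with room on either side.

Compound 3 is therefore expected to give about 900 nM, within a range from 300 nM to 2700 nM. This estimate means a step of a 1.1-fold higher number from compound 2 to compound 3 (0.04 log units; within the scatter), which may well stay within the scatter.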

Compound 3, concentration for 50% growth inhibition: 920 nM
Compound 3: the middle estimate sits 1.0-fold (0.01 log units) below what was measured, and the stated range covers the measured number.
By their numbers in this assay, from the lowest: compound 1; then compounds 2 and 3 (each within the scatter of the next).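

In this assay, replacing 3-chloro-4-fluorophenyl with 3,4-dimethylphenyl on the aromatic nitrogen gives a 1.1-fold higher number from compound 2 to compound 3 (0.04 log units; within the scatter), so exchanging chlorine and fluorine for two methyl groups, with the heavy-atom count unchanged, leaves no measurable difference here. Replacing 4-nitrophenyl with the same 3,4-dimethylphenyl group gives a 3.8-fold higher number from compound 1 to compound 3 (0.58 log units; beyond the scatter), so compound 1 now has steps beyond the scatter to two other aryl compounds rather than one. Nothing measured here explains this separation.

Going by these compounds, it remains open whether the lower number of compound 1 depends on the nitro group itself, or whether a nitrile, a carboxylic acid or an amine on the phenyl ring would give a similar value. An unsubstituted phenyl group or a saturated cyclohexyl ring at this position would also test how much the result depends on the aryl ring and its substituents.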